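A few compounds are considered here, and "the series" means these few. Any claim that something is new, unique, unknown or untested is made for them only; others in the source may bear on it.

Three compounds built on a shared core were measured in a functional assay on LOX IMVI cells (Homo sapiens) for inhibition, read by sulforhodamine B assay, with a stated time of 48 h, tested at 10 uM; a lower number here means less inhibition, a higher number more inhibition at the concentration tested (going by the name of the read-out). Compound 1 `Brc1cn2ccnc2c(-c2ccc3ncn(C4CCCCC4)c3c2)n1` carries a bromo group and gives 15.2%. Compound 2 `c1ccc2c(-c3cn4ccnc4c(-c4ccc5ncn(C6CCCCC6)c5c4)n3)cccc2c1` has naphthalen-1-yl in place of bromo on an aromatic carbon and gives 7.43%. Compound 3 `c1csc(-c2cn3ccnc3c(-c3ccc4ncn(C5CCCCC5)c4c3)n2)c1` has thiophen-2-yl in place of bromo on an aromatic carbon and gives 1.07%. Compound 2 stands second highest of the three numbers; both of its neighbours lie within the scatter, as seen in a number 7.8 percentage points lower from compound 1 to compound 2 (within the scatter) and in a number 6.4 percentage points lower from compound 2 to compound 3 (within the scatter). Going by the values given here, only one measured step reaches beyond the scatter: a number 14.1 percentage points lower from compound 1 to compound 3 (beyond the scatter).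

Compound 4 `c1ccc(Cn2cnc3ccc(-c4nc(-c5cccc6ccccc56)cn5ccnc45)cc32)cc1` differs from compound 2 in one place: benzyl in place of cyclohexyl on an aromatic nitrogen. Among the compounds with values here, none of the measured steps touches this ring nitrogen; all three swap the group on the aromatic carbon, so no measured step bears directly on this change. With nothing to point to a shift, a step within the scatter is expected, a number 0.6 percentage points higher from compound 2 to compound 4 (within the scatter). Compound 4 is therefore estimated at 8%, with a likely range from -5% to 25%.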

Compound 4, a percentage reported as inhibition, at one concentration (the size of the read-out at that concentration, not a potency): 16.5%
Estimate against measurement, compound 4: 8.5 percentage points below, within the range that was stated.
By their numbers in this assay, from the lowest: compounds 3, 2, 1 and 4 (each within the scatter of the next, the first and the last beyond it).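

Going by these compounds alone, this is the first time the group on the aromatic nitrogen varies, as the earlier compounds all carry cyclohexyl there. In this assay, with naphthalen-1-yl kept on the aromatic carbon, benzyl in place of cyclohexyl gives a number 9.1 percentage points higher from compound 2 to compound 4 (within the scatter) and so does not separate the two groups at this position, even though one brings an aromatic ring and the other a non-aromatic one. No measurement shown here offers an explanation for this result.

From the compounds shown here alone, this reading rests on one pair, so it remains open whether benzyl and cyclohexyl would also stay this close with bromo or thiophen-2-yl on the aromatic carbon. Only groups made of carbon alone appear on this nitrogen, which leaves open how a longer chain ending in an amine would read out there.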